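The compounds below may be only part of what the source reports. "The series", "measured", "known", "first", "only" and "open" are said of these compounds alone.

Compound 1 `CCCn1c(=O)c2nc(C(C)C)[nH]c2n(CCC)c1=O` is one of two compounds whose affinity has been measured in an assay on cell membranes for binding affinity to adenosine receptor A1 (Cavia porcellus); a lower number here means a stronger inhibitor, a higher number a weaker inhibitor. In this assay compound 1 gives 49 nM, the lowest of the two numbers. The other measured compound, compound 2 `CCCn1c(=O)c2nc(C(C)Cc3ccc(OC)cc3)[nH]c2n(CCC)c1=O`, gives 220 nM in this assay, and the change from compound 1 to compound 2 came with a 4.5-fold higher number from compound 1 to compound 2 (0.65 log units; beyond the scatter), a change made on a saturated chain carbon rather than on the ring.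

Compound 3 `CCCC(CCC)c1nc2c(=O)n(CCC)c(=O)n(CCC)c2[nH]1` has not yet been measured in this assay. It differs from compound 1 in one place: 1-propylbutyl in place of isopropyl on an aromatic carbon. Within the data shown here, the only measured step is the one from compound 1 to compound 2, which enlarged the same group at a different spot and gave a modest weakening; no step in which the isopropyl itself is exchanged for a larger chain on the aromatic carbon has been measured. On that slim basis a modest weakening is expected for compound 3, a shift of about a 2.4-fold higher number from compound 1 to compound 3 (0.39 log units; beyond the scatter) in this assay, with the whole range from no change to a clear loss staying possible. Compound 3 is therefore expected to give about 120 nM in this assay, with the likely span running from 40 nM to 400 nM.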

Compound 3, inhibition constant: 78 nM
Estimate against measurement, compound 3: 1.5-fold (0.19 log units) above; the measured number falls inside the stated range.
By their numbers in this assay, from the lowest: compounds 1 and 3 (each within the scatter of the next); then compound 2.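

Replacing isopropyl with 1-propylbutyl on the aromatic carbon between two ring nitrogen atoms gave a 1.6-fold higher number from compound 1 to compound 3 (0.20 log units; within the scatter) in this assay, so compounds 1 and 3 cannot be told apart in their numbers even though the group grows from 3 heavy atoms to 7. Enlarging the group at this carbon therefore does not always bring a loss: the step that added 4-methoxyphenyl on a saturated chain carbon, a 4.5-fold higher number from compound 1 to compound 2 (0.65 log units; beyond the scatter), lay beyond the scatter, whereas the step to the all-carbon 1-propylbutyl group did not. No independent measurement is available to explain why these two enlargements differ.

From the compounds shown here alone, with only these compounds, it remains open whether the loss seen with 4-methoxyphenyl goes with the aromatic ring, its methoxy group or the way the group is attached, and a plain phenyl or a cyclopentyl group on the same aromatic carbon would help separate these possibilities. Going by these compounds, how far the chain can grow also remains open, as does whether a longer chain such as 1-pentylhexyl would still stay within the scatter of compound 1.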